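Working notes: from compound 3 to compound 4

The compounds below may be only part of what the source reports. "The series", "measured", "known", "first", "only" and "open" are said of these compounds alone.

Measured so far:
compound 1 `COc1ccc(-c2nc(/N=C(\N)NC(C)C)sc2-c2ccc(OC)cc2)cc1`: 9.1 uM
compound 2 `COc1ccc(-c2nc(/N=C(\N)[N+]3(C)CCCCC3)sc2-c2ccc(OC)cc2)cc1`: 21 uM
compound 3 `COc1ccc(-c2nc(CN(C)C)sc2-c2ccc(OC)cc2)cc1`: 8.4 uM

All three were run in a functional assay (aorta) with Rattus norvegicus as the target; a lower number here means that less compound is needed, a higher number that more compound is needed for the effect. Compound 3 gives the lowest of the three numbers, but compound 1 sits within the scatter of it (a 1.1-fold lower number from compound 1 to compound 3 (0.03 log units; within the scatter)), so the two cannot be ordered. Only compound 2 stands apart: a 2.3-fold higher number from compound 1 to compound 2 (0.36 log units; beyond the scatter) and a 2.5-fold lower number from compound 2 to compound 3 (0.40 log units; beyond the scatter), both modest steps beyond the scatter, and both tied to the group with the six-membered non-aromatic ring.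

Compound 4 `COc1ccc(-c2nc(CNC(=O)NC(C)C)sc2-c2ccc(OC)cc2)cc1` has not yet been measured. It differs from compound 3 in one place: (isopropylcarbamoyl)amino in place of dimethylamino on a saturated chain carbon bound to an aromatic carbon. The (isopropylcarbamoyl)amino group brings two hydrogen-bond donors and a double bond outside aromatic rings where the dimethylamino group had none; it also carries an isopropyl, as the group on compound 1 does. The step that bears most on this is a 1.1-fold lower number from compound 1 to compound 3 (0.03 log units; within the scatter), which shows that exchanging a small chain amine for a larger chain group carrying nitrogen and an isopropyl moved the number hardly at all. Nothing in the series shows a carbonyl at this position, so the expectation rests on that one comparison. A step within the scatter, or at most a modest rise, is expected: a 1.2-fold higher number from compound 3 to compound 4 (0.08 log units; within the scatter). Compound 4 is therefore estimated at 10 uM, with a range from 4 uM to 30 uM.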

Compound 4, concentration for half-maximal effect: 5.7 uM
Beside the measured number, compound 4's estimate is 1.8-fold (0.24 log units) above it; measured number inside the range.
By their numbers in this assay, from the lowest: compounds 4, 3 and 1 (each within the scatter of the next); then compound 2.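

In this assay, the saturated chain carbon bound to an aromatic carbon takes (isopropylcarbamoyl)amino in place of dimethylamino with no step beyond the scatter (a 1.5-fold lower number from compound 3 to compound 4 (0.17 log units; within the scatter)), so this place accommodates a larger group that brings a carbonyl and hydrogen-bond donors without a readable change in the number. Within the data shown here, the new compound also cannot be ordered against the compound with the isopropyl group on a carbon with a double bond to nitrogen (a 1.6-fold lower number from compound 1 to compound 4 (0.20 log units; within the scatter)), while the compound with the six-membered non-aromatic ring remains apart by a modest step (a 3.7-fold lower number from compound 2 to compound 4 (0.57 log units; beyond the scatter)), the largest printed so far. No measurement in hand accounts for these results.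

The carbonyl and the isopropyl enter together in compound 4, so the compounds shown cannot tell what either does alone at this place. From the compounds shown here alone, how a carboxylic acid, a primary amine or a longer chain would read there remains open, as does whether the tolerance seen here would hold in any other read-out.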